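The source may report more compounds than this note shows. Statements on the series, on what has been measured and on what is new or still open speak of the compounds shown alone.

In an ADME assay on RAW264.7 cells (Mus musculus) for cytotoxicity, read by MTT assay, with a stated time of 18 h (a higher number here means that more compound is tolerated, a lower number that less compound is tolerated), compound 1 `C=C1C(=O)OC[C@@H]1CCOC(=O)Nc1ccc(C(C)C)cc1` gives 15300 nM, which lies within the scatter of the other two measured compounds, so the three values carry no order. Compound 2 `C=C1C(=O)OC[C@H]1CCOC(=O)Nc1cccc(Br)c1` gives 21800 nM and compound 3 `C=C1C(=O)OC[C@@H]1CCOC(=O)Nc1ccc(F)cc1F` gives 14800 nM. Compound 4 `C=C1C(=O)OC[C@@H]1CCOC(=O)Nc1ccc(I)cc1` has iodo in place of the isopropyl of compound 1, on an aromatic carbon, para to a large group: iodo in place of isopropyl on an aromatic carbon. Going by the values given here, no measured pair differs in one place, so this expectation rests on thin evidence. With ring substituents that differ, compound 2 at 21800 nM and compound 3 at 14800 nM stay within the scatter of compound 1, so no step beyond the scatter is expected in this assay. The expected change is a 1.0-fold lower number from compound 1 to compound 4 (0.01 log units; within the scatter). For compound 4 the estimate is 15000 nM, with an expected range of 7500 nM to 30000 nM.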

Compound 4, half-maximal cytotoxic concentration: 12500 nM
Compound 4: the middle estimate sits 1.2-fold (0.08 log units) above what was measured; the range from low to high includes it.
By their numbers in this assay, from the lowest: compounds 4, 3, 1 and 2 (each within the scatter of the next).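

In this assay, going by these compounds alone, iodo in place of isopropyl on an aromatic carbon, para to a large group, gives a 1.2-fold lower number from compound 1 to compound 4 (0.09 log units; within the scatter) as the first single-place comparison. At this position, a single iodine and a group of three carbons are not told apart by this read-out. No measurement in hand bears on why the two groups match.

On these data alone, whether an amine, a carboxylic acid or a longer chain at this position would give a step beyond the scatter remains open. As far as these compounds go, the same change at other places on the ring is also open.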